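Working notes on the step from compound 1 to compound 4

A few compounds are considered here, and "the series" means these few. Any claim that something is new, unique, unknown or untested is made for them only; others in the source may bear on it.

Measured so far:
compound 1, `CCCCCCCNC(=N)NC(=N)Nc1ccc(F)c(F)c1`, 4300 nM
compound 2, `CC(C)CNC(=N)NC(=N)Nc1ccc(C(F)(F)F)cc1`, 3100 nM
compound 3, `N=C(NC(=N)NC1CCCC1)Nc1ccc(F)cc1F`, 37800 nM

In a functional assay on T-24 cells (Homo sapiens) for antiproliferative activity, read by MTT assay, with a stated time of 72 h (on this read-out higher numbers stand for weaker inhibition and lower numbers for stronger inhibition), compound 1 gives 4300 nM, the second highest of the three numbers. Compound 2 is nearest, within the scatter of compound 1; compound 3 is furthest, its number beyond the scatter above compound 1. Compound 4, `CC(C)CNC(=N)NC(=N)Nc1ccc(F)c(F)c1`, is not yet measured. It differs from compound 1 by isopropyl in place of hexyl on a saturated chain carbon bound to an amine nitrogen. Within the data shown here, no step between measured compounds shares this change, so nothing directly anchors its size. Compound 2, which carries isobutyl on a different core, gives 3100 nM, close to compound 1. In this assay the expected step is a 1.0-fold higher number from compound 1 to compound 4 (0.02 log units; within the scatter), within the scatter in either direction. Compound 4 is estimated at 4500 nM, between 1500 nM and 14000 nM.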

Compound 4, half-maximal inhibitory concentration: 42900 nM
Beside the measured number, compound 4's estimate is 9.5-fold (0.98 log units) below it; measured number outside the range, above it.
By their numbers in this assay, from the lowest: compounds 2 and 1 (each within the scatter of the next); then compounds 3 and 4 (each within the scatter of the next).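

In this assay, the group on the amine nitrogen is no silent position on the shared core: isopropyl in place of hexyl on a saturated chain carbon bound to an amine nitrogen gives a 10-fold higher number from compound 1 to compound 4 (1.00 log units; beyond the scatter) and so weakens inhibition. Among these compounds, this is the first step read at this position, and the group with fewer carbons goes with the higher number. Nothing measured on these compounds accounts for the step. Going by these compounds, whether the step follows chain length or branching stays open. A straight butyl chain or a longer chain such as octyl on the same core would separate the two.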